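This account rests on a few compounds, and the source may have more. Where it says the series, first, only, none or still open, it means among the compounds named here.

Working notes on the series. The set shares one saturated bicyclic amine core; the variable part is the aromatic group attached through a methylene to the amine nitrogen. In an ADME assay on MDCK cells (Canis lupus familiaris) for cytotoxicity, read by microscopy, with a stated time of 48 h (on this read-out higher numbers stand for lower toxicity in this test and lower numbers for higher toxicity in this test), compound 1 `CCc1csc(CN[C@@H]2C[C@H]3C[C@@H]([C@H]2C)C3(C)C)c1` gives 25000 nM. In this assay compound 2 `CCc1ccc(CN[C@@H]2C[C@H]3C[C@@H]([C@H]2C)C3(C)C)s1` gives 1560 nM. In this assay compound 3 `C[C@H]1[C@H](NCc2ccsc2)C[C@H]2C[C@@H]1C2(C)C` gives 50000 nM; compound 3 and compound 1 lie within the scatter of each other, so no order between them is claimed, whereas compound 2 sits beyond the scatter with the lower number.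

Compound 4 `C[C@H]1[C@H](NCc2ccc(Cl)s2)C[C@H]2C[C@@H]1C2(C)C` differs from compound 3 by 5-chlorothiophen-2-yl in place of thiophen-3-yl on a saturated chain carbon bound to an amine nitrogen. For this change a step downward beyond the scatter is expected in this assay, the step of an 8.3-fold lower number from compound 3 to compound 4 (0.92 log units; beyond the scatter) being the estimate, because compound 2, which also carries a 2-substituted thiophene, gives 1560 nM. Compound 4 is expected to give 6000 nM, with a range from 1500 nM to 25000 nM.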

Compound 4, minimum cytotoxic concentration: 25000 nM
Estimate against measurement, compound 4: 4.2-fold (0.62 log units) below, within the range that was stated.
By their numbers in this assay, from the lowest: compound 2; then compounds 1, 4 and 3 (each within the scatter of the next).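

In this assay, 5-chlorothiophen-2-yl in place of thiophen-3-yl on a saturated chain carbon bound to an amine nitrogen leaves the number within the scatter (a 2.0-fold lower number from compound 3 to compound 4 (0.30 log units; within the scatter)). Chloro in place of ethyl on an aromatic carbon gives a large rise (a 16-fold higher number from compound 2 to compound 4 (1.20 log units; beyond the scatter)), so a thiophen-2-yl group alone does not go with the low number of compound 2. No measurement available here explains this rise.

Open, from the compounds shown here alone, is how a carboxylic acid or an amine in place of that chloro would read in this assay. Also open, going by these compounds, is a propyl chain there.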